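The source may hold more compounds than are shown below. What is called first, only, known or untested is meant among the compounds shown, and "the series" means these compounds.

Compound 3 `O=C(/C=C/c1ccccc1)c1ccc(N2CCN(S(=O)(=O)c3ccc(Cl)cc3)CC2)cc1` carries a (4-chlorophenyl)sulfonyl group on the amine nitrogen in the ring of the shared core. In a functional assay on the whole organism (strain Kunming) for inhibition, with Mus musculus as the target, with a stated time of 1 h, at a dose of 40 mg/kg by the oral route (on this read-out lower numbers stand for less inhibition and higher numbers for more inhibition at the one dose given (going by the name of the read-out)), compound 3 gives 46.8%, the highest of the three numbers measured. Compound 1 `O=C(/C=C/c1ccccc1)c1ccc(N2CCN(c3cccc(Cl)c3Cl)CC2)cc1` gives 30.7% and compound 2 `O=C(/C=C/c1ccccc1)c1ccc(N2CCN(c3cccc(C(F)(F)F)c3)CC2)cc1` gives 25%. The step of a number 16.1 percentage points higher from compound 1 to compound 3 (beyond the scatter) and the step of a number 21.8 percentage points higher from compound 2 to compound 3 (beyond the scatter) both lie beyond the scatter, while the step of a number 5.7 percentage points lower from compound 1 to compound 2 (within the scatter) stays within it.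

Compound 4 `COc1ccc(S(=O)(=O)N2CCN(c3ccc(C(=O)/C=C/c4ccccc4)cc3)CC2)cc1` differs from compound 3 in one place: methoxy in place of chloro on an aromatic carbon. The exchanged group sits on an aromatic carbon, para to a large group, and the sulfonyl attachment to the ring nitrogen that compound 3 has is kept. Within the data shown here, none of the measured steps exchanges one group for another on this outer ring; they only swap the whole group on the ring nitrogen, so they give no direct guide to this change. The expectation is therefore no step beyond the scatter. Compound 4 is estimated at 45%, with a range from 30% to 60%. This estimate means an expected step of a number 1.8 percentage points lower from compound 3 to compound 4 (within the scatter).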

Compound 4, a percentage reported as inhibition, in the whole organism at one dose (the size of the read-out at that dose, not a potency): 45.2%
Compound 4: middle estimate off by 0.2 percentage points, on the low side; the range from low to high includes it.
By their numbers in this assay, from the lowest: compounds 2 and 1 (each within the scatter of the next); then compounds 4 and 3 (each within the scatter of the next).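

In this assay, exchanging chloro for methoxy on the outer aromatic ring gives a number 1.6 percentage points lower from compound 3 to compound 4 (within the scatter), so at this position the two groups cannot be told apart. The sulfonyl link keeps its lead with the new group too, with a number 20.2 percentage points higher from compound 2 to compound 4 (beyond the scatter) and a number 14.5 percentage points higher from compound 1 to compound 4 (beyond the scatter), so the higher numbers seen so far do not depend on the chloro group. No measurement here explains why this exchange leaves the number within the scatter.

On these data alone, with only chloro and methoxy at this place, it remains open whether an amine, a carboxylic acid or a longer alkoxy chain such as butoxy would also hold the number. A single dose also leaves open how these compounds would compare at other doses.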